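Working notes: the step from compound 3 to compound 4

This account rests on a few compounds, and the source may have more. Where it says the series, first, only, none or still open, it means among the compounds named here.

Measured so far in a functional assay (trachea) with Rattus norvegicus as the target; a lower number here means a less potent compound, a higher number a more potent compound, by a factor of ten per unit of this negative logarithm:
compound 1 `CC1(C)C=C(n2ccccc2=O)c2ccccc2O1`: 5.05
compound 2 `CC1(C)C=C(n2ccccc2=O)c2cc(C(=O)c3ccccc3)ccc2O1`: 6.21
compound 3 `CC1(C)C=C(n2ccccc2=O)c2cc(O)ccc2O1`: 5.31

Compound 3 stands second highest of the three numbers. Its nearest neighbour is compound 1, with a number 0.26 log units higher from compound 1 to compound 3 (within the scatter); its furthest is compound 2, with a number 0.90 log units lower from compound 2 to compound 3 (beyond the scatter). For the measured compounds named here, the only large step in the set is a number 1.16 log units higher from compound 1 to compound 2 (beyond the scatter).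

Compound 4 `CC1(C)C=C(n2ccccc2=O)c2cc(OS(=O)(=O)F)ccc2O1` has not been measured. It differs from compound 3 in one place: fluorosulfonyl in place of hydrogen on an oxygen on an aromatic ring.

Going by the values given here, no measured step touches the oxygen on the aromatic ring; the three known steps all concern the aromatic carbon itself. Of these, the hydroxy step is within the scatter and the benzoyl step is large, which shows that a larger group at this part of the shared core can be rewarded, but gives no direct guide to (fluorosulfonyl)oxy. The expectation is therefore cautious: a step upward of at most modest size, possibly none beyond the scatter.

In this assay compound 4 is expected to give 5.6, with a range from 5 to 6.3. The step this estimate means, a number 0.29 log units higher from compound 3 to compound 4 (within the scatter), is expected to be small.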

Compound 4, logarithm of the reciprocal of the active concentration, log(1/C): 7.22
For compound 4 the middle estimate is 1.62 log units below the measured one; the whole stated range lies below it.
By their numbers in this assay, from the lowest: compounds 1 and 3 (each within the scatter of the next); then compound 2; then compound 4.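

In this assay, for the compounds shown here, a number 1.91 log units higher from compound 3 to compound 4 (beyond the scatter), so the oxygen on the aromatic ring, which no earlier step touched, is a place where a change can carry a large step, although hydroxy in place of hydrogen on the aromatic carbon stayed within the scatter. At that aromatic carbon, (fluorosulfonyl)oxy also surpasses the best earlier group, with a number 1.01 log units higher from compound 2 to compound 4 (beyond the scatter), and it stands well above hydrogen, with a number 2.17 log units higher from compound 1 to compound 4 (beyond the scatter), so benzoyl no longer marks the top of the series and compound 4 is the most potent of the four. No measurement in hand accounts for the size of these steps. 

The compounds shown leave open whether the gain belongs to the fluorosulfonyl group itself or would come with other groups on this oxygen, such as methyl, acetyl or methanesulfonyl. They also leave open how far the step depends on the sulfur-bound fluorine, which the same oxygen carrying a sulfamoyl group would test.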